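The source may report more compounds than this note shows. Statements on the series, on what has been measured and on what is new or still open speak of the compounds shown alone.

Measured in a functional assay on HeLa cells (Homo sapiens) for inhibition, read by sulforhodamine B assay; on this read-out higher numbers stand for weaker inhibition and lower numbers for stronger inhibition:
- compound 1 `O=C1C=C(Nc2ccccc2F)C(=O)c2c1nc1n2[C@H]2OC[C@@H](O)[C@H]2OC1` at 5120 nM
- compound 2 `COc1ccccc1NC1=CC(=O)c2c(nc3n2[C@H]2OC[C@@H](O)[C@H]2OC3)C1=O` at 7460 nM

In this assay, among the measured compounds shown here, compound 1 at 5120 nM and compound 2 at 7460 nM lie within the usual scatter of each other, so neither ranks ahead and compound 1 stands level with the only other number available. Compound 3 `O=C1C=C(NC2CCCC2)C(=O)c2c1nc1n2[C@H]2OC[C@@H](O)[C@H]2OC1` keeps the core of compound 1 and carries cyclopentyl in place of 2-fluorophenyl on an amine nitrogen, counted as cyclopentyl in place of 2-fluorophenyl on an amine nitrogen in full. For the measured compounds named here, no measured step between compounds differing in one place exists to guide this change, so no step beyond the scatter is expected in this assay and no direction is favoured. The estimated change is a 1.2-fold higher number from compound 1 to compound 3 (0.07 log units; within the scatter) and remains uncertain. For compound 3 the expected value is 6000 nM within an estimated range of 1800 nM to 20000 nM in this series.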

Compound 3, half-maximal inhibitory concentration: > 16000 nM
Compound 3: no number, only a limit; the forecaster's own chance of this, stated with the estimate: 10%; at least 2.6-fold (0.42 log units) between middle value and limit.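

In this assay compound 3 gives > 16000 nM, which is a limit of the assay and not a number. Cyclopentyl in place of 2-fluorophenyl on an amine nitrogen gives an at least 3.1-fold higher number from compound 1 to compound 3 (0.49 log units; beyond the scatter), the first readable step at this position and one that shows the group here is not interchangeable in this series. The step marks weaker inhibition, but its full size remains unread: the limit of > 16000 nM in this assay, at which 1 of the 3 values shown sits.

This single change replaces a six-membered aromatic ring with a five-membered non-aromatic ring, so the contributions of ring size and aromatic character cannot be separated. From the compounds shown here alone, how cyclohexyl, benzyl or an open alkyl chain on the same amine nitrogen would read in this assay remains open.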